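Methylsulfanyl in place of aminoamino on the shared core

A few compounds are considered here, and "the series" means these few. Any claim that something is new, unique, unknown or untested is made for them only; others in the source may bear on it.

Measured compounds:
compound 1 `CSc1nc(-c2ccccc2O)c(C#N)c(=O)n1C`, a functional assay, with a stated time of 10 min; on this read-out lower numbers stand for stronger inhibition and higher numbers for weaker inhibition: 39 ug/mL
compound 2 `Cn1c(NN)nc(-c2ccccc2Cl)c(C#N)c1=O`, this assay: 46 ug/mL

Within the data shown here, compound 2 stands highest of the two numbers measured so far, but its nearest neighbour, compound 1, gives a number only a little lower, and that gap lies within the scatter of repeated measurements. Among the measured compounds shown here, no step between two measured compounds that differ in one place is available, so nothing is yet known about how any single change moves this read-out.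

Compound 3 `CSc1nc(-c2ccccc2Cl)c(C#N)c(=O)n1C` has not been measured. It differs from compound 2 by methylsulfanyl in place of aminoamino on an aromatic carbon. For the measured compounds named here, since no comparable step has been measured, the expectation rests on the two values in hand, which lie close together. The step from compound 2 to compound 3 is expected to be small, a 1.2-fold lower number from compound 2 to compound 3 (0.06 log units; within the scatter), and not beyond the scatter. For compound 3 the estimate is 40 ug/mL, with a range from 15 ug/mL to 100 ug/mL, because compound 1 gives 39 ug/mL and compound 2 gives 46 ug/mL.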

Compound 3, half-maximal inhibitory concentration: 67 ug/mL
Compound 3: the middle estimate sits 1.7-fold (0.22 log units) below what was measured; measured number inside the range.
By their numbers in this assay, from the lowest: compounds 1, 2 and 3 (each within the scatter of the next).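

In this assay, among these compounds, putting methylsulfanyl in place of aminoamino on the aromatic carbon between two ring nitrogen atoms gives a 1.5-fold higher number from compound 2 to compound 3 (0.16 log units; within the scatter) and provides the first reading of a single change at this position. Aminoamino, with its 2 hydrogen-bond donors, can therefore give way to methylsulfanyl, with 0, without a shift that exceeds the scatter. The second change, chloro in place of hydroxy on an aromatic carbon, gives a 1.7-fold higher number from compound 1 to compound 3 (0.24 log units; within the scatter) and likewise stays inside the scatter.

These compounds leave open whether a simple amine, a methoxy group or a longer alkylsulfanyl chain at the same carbon would move the number beyond the scatter. No measurement shown here bears on what lies behind either step.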